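Swapping 3-nitrophenyl for pyridin-2-yl on a shared core

The source may report more compounds than this note shows. Statements on the series, on what has been measured and on what is new or still open speak of the compounds shown alone.

Of the compounds shown here, three sharing one core have been tested in a functional assay on K562 cells (Homo sapiens) for antiproliferative activity, read by MTT assay, with a stated time of 24 h; a lower number here means a stronger inhibitor, a higher number a weaker inhibitor. Compound 1 `COc1ccc(C(=O)/C=C/c2ccc(Br)cc2)c2c1C=CC(C)(C)O2` gives > 10000 nM, which is a limit of the assay and not a number. Compound 2 `COc1ccc(C(=O)/C=C/c2ccc([N+](=O)[O-])cc2)c2c1C=CC(C)(C)O2` gives 7770 nM, and compound 3 `COc1ccc(C(=O)/C=C/c2cccc([N+](=O)[O-])c2)c2c1C=CC(C)(C)O2` gives 5870 nM. These two values lie within the scatter of each other, so compound 3 stands level with compound 2.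

Compound 4 `COc1ccc(C(=O)/C=C/c2ccccn2)c2c1C=CC(C)(C)O2` differs from compound 3 in one place, with pyridin-2-yl in place of 3-nitrophenyl on a double-bonded chain carbon bound to a double-bonded chain carbon. For the measured compounds named here, no tested compound carries pyridin-2-yl, so the evidence is indirect. The three measured steps all change the same aromatic group. They are a 1.3-fold lower number from compound 2 to compound 3 (0.12 log units; within the scatter), an at least 1.2-fold lower number from compound 1 to compound 2 (0.10 log units; that floor lies within the scatter) and an at least 1.7-fold lower number from compound 1 to compound 3 (0.23 log units; that floor lies within the scatter). The last two are only floors, and none of the three goes beyond the scatter. A step beyond the scatter is therefore not expected in this assay. The estimated step is a 1.2-fold higher number from compound 3 to compound 4 (0.08 log units; within the scatter). For compound 4 the estimated value is 7000 nM, with an expected range of 3000 nM to 10000 nM.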

Compound 4, half-maximal inhibitory concentration: 5400 nM
Estimate against measurement, compound 4: 1.3-fold (0.11 log units) above; low and high end bracket the measured number.
By their numbers in this assay, from the lowest: compounds 4, 3 and 2 (each within the scatter of the next). At a limit, above all of these: compound 1.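

In this assay, for the compounds shown here, the group on this double-bonded chain carbon now carries a nitrogen in its aromatic ring and no nitro or bromo group, and this is the first such ring. Even so, the result is a 1.1-fold lower number from compound 3 to compound 4 (0.04 log units; within the scatter) and a 1.4-fold lower number from compound 2 to compound 4 (0.16 log units; within the scatter), so compound 4 stands level with both nitro compounds, and a ring of carbon only with a nitro group is not needed to stay at this level. The comparison with compound 1 gives an at least 1.8-fold lower number from compound 1 to compound 4 (0.26 log units; that floor lies within the scatter), which is only a floor, as the value of compound 1 is a limit of the assay and not a number: the limit of > 10000 nM in this assay, at which 1 of the 4 values shown sits.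

As far as these compounds go, it remains open whether an amine, a carboxylic acid or a longer chain on this carbon would give a step beyond the scatter. Whether any group here can bring a clearly lower number also stays unanswered.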